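The source may report more compounds than this note shows. Statements on the series, on what has been measured and on what is new or still open speak of the compounds shown alone.

Compound 1, whose structure is `Cc1ccccc1Cn1cc(COc2ccc3c(=O)ccoc3c2)nn1`, was tested in a functional assay on SGC-7901 cells (Homo sapiens) for cytotoxicity, read by MTT assay, with a stated time of 48 h; a higher number here means a weaker inhibitor, a lower number a stronger inhibitor. In this assay compound 1 gives > 100000 nM, which is a limit of the assay rather than a measured number. Compound 2, a smaller relative with the structure `C#CCOc1ccc2c(=O)ccoc2c1`, was tested the same way. In this assay compound 2 gives > 100000 nM, again a limit. Compound 1 therefore stands at the limit of > 100000 nM in this assay, at which 2 of the 2 values shown sit, so nothing shown sets it apart from the only other value.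

Compound 3, with the structure `O=c1ccoc2cc(OCc3cn(Cc4cccc(Cl)c4)nn3)ccc12`, has not yet been measured. It differs from compound 1 in one place: 3-chlorophenyl in place of 2-methylphenyl on a saturated chain carbon bound to an aromatic nitrogen. Neither group brings a hydrogen-bond donor or acceptor, and no measured step joins two of these compounds. In this assay the step of a number no higher from compound 1 to compound 3 (the limit leaves the size open) is expected to be none beyond the scatter. Compound 3 is therefore estimated at 100000 nM, within a range from 40000 nM to 300000 nM.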

Compound 3, half-maximal inhibitory concentration: > 100000 nM
Compound 3: no number, only a limit; the forecaster's own chance of this, stated with the estimate: 80%; the middle value sits exactly at the limit.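

No step can be read from compound 1 to compound 3, because neither gives a number, only a limit of the assay: the limit of > 100000 nM in this assay, at which 3 of the 3 values shown sit.

In this assay the compounds shown leave open whether 2-methylphenyl and 3-chlorophenyl differ at all, and which change to the shared core would give a measurable value.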